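Chloro to 4-Methylphenyl: Expected Shift in Cytotoxicity

The source may report more compounds than this note shows. Statements on the series, on what has been measured and on what is new or still open speak of the compounds shown alone.

The measured compounds, in an ADME assay on J774.A1 cells (Mus musculus) for cytotoxicity, read by MTT assay, with a stated time of 72 h; on this read-out lower numbers stand for higher toxicity in this test and higher numbers for lower toxicity in this test:
Compound 1, `CC1(Cc2ccccc2)CC(S(=O)(=O)c2cccc(F)c2)=C(c2ccc(/C(N)=N\O)cc2)O1`, gives 28300 nM.
Compound 2, `CC1(c2ccc(-c3ccccc3C#N)cc2)CC(S(=O)(=O)c2ccc(F)cc2)=C(c2ccc(/C(N)=N\O)cc2)O1`, gives 9290 nM.
Compound 3, `CC1(c2ccc(Cl)cc2)CC(S(=O)(=O)c2ccc(F)cc2)=C(c2ccc(/C(N)=N\O)cc2)O1`, gives 31500 nM.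

Compound 3 stands highest of the three numbers. Its nearest neighbour is compound 1, whose value lies within the scatter of that of compound 3, so no order between these two can be claimed. For the measured compounds named here, compound 2 lies furthest away, and the one step that joins two of the measured compounds runs from it to compound 3: a 3.4-fold higher number from compound 2 to compound 3 (0.53 log units; beyond the scatter). That step swapped an aryl group on an aromatic carbon for a chloro substituent and raised the number.

Compound 4, `Cc1ccc(-c2ccc(C3(C)CC(S(=O)(=O)c4ccc(F)cc4)=C(c4ccc(/C(N)=N\O)cc4)O3)cc2)cc1`, reverses that kind of change: 4-methylphenyl in place of chloro on an aromatic carbon. Going by the values given here, the one relevant step is the one from compound 2 to compound 3, which was modest and beyond the scatter, so for compound 4 a step of about the same size in the opposite direction in this assay is expected, toward a lower number, landing near the value of compound 2. Compound 4 is therefore estimated at 10000 nM, with a range from 3500 nM to 28000 nM, which means a step of a 3.2-fold lower number from compound 3 to compound 4 (0.50 log units; beyond the scatter).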

Compound 4, half-maximal cytotoxic concentration: 7910 nM
Beside the measured number, compound 4's estimate is 1.3-fold (0.10 log units) above it, and the stated range covers the measured number.
By their numbers in this assay, from the lowest: compounds 4 and 2 (each within the scatter of the next); then compounds 1 and 3 (each within the scatter of the next).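

In this assay the change from chloro to 4-methylphenyl, on an aromatic carbon para to a large group, gives a 4.0-fold lower number from compound 3 to compound 4 (0.60 log units; beyond the scatter), so this position now has two separate swaps away from chloro that both end at a lower number, which here means higher toxicity in this test. The new comparison between the two aryl groups gives a 1.2-fold lower number from compound 2 to compound 4 (0.07 log units; within the scatter), so 4-methylphenyl and 2-cyanophenyl cannot be told apart at this position, and the nitrile that compound 2 carries on its added ring shows no separate effect on the number beyond what compound 4 gives without it. No measurement shown offers any explanation for the shift at this position.

On these data alone, whether the lower number goes with a six-membered aromatic ring in general or only with these two aryl groups remains open, and plain phenyl would help to decide that. As far as these compounds go, it is equally open how an amine, a carboxylic acid or a longer alkyl chain on this aromatic carbon would compare with chloro in this assay.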